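The compounds below may be only part of what the source reports. "The series", "measured", "known", "first", "only" and "open" are said of these compounds alone.

Compound 1 `CC1=CC[C@H](C(C)(C)NC(=S)N/N=C/c2ccccc2)CC1` gives 13000 nM in a functional assay on NCI-H460 cells (Homo sapiens) for inhibition, read by sulforhodamine B assay, with a stated time of 48 h; a lower number here means a stronger inhibitor of growth, a higher number a weaker inhibitor of growth. Compound 2 `CC1=CC[C@H](C(C)(C)NC(=S)N/N=C/c2ccccc2O)CC1` gives 1900 nM.

Within the data shown here, compound 1 stands at the higher of the two numbers; the only measured step, a 6.8-fold lower number from compound 1 to compound 2 (0.84 log units; beyond the scatter), adds a hydroxy group and leaves the ring itself untouched. Compound 3 `CC1=CC[C@H](C(C)(C)NC(=S)N/N=C/c2cccs2)CC1` differs from compound 1 by thiophen-2-yl in place of phenyl on a carbon with a double bond to nitrogen. Among the measured compounds shown here, no measured step exchanges the aromatic ring, so the hydroxy step does not bear on this change. The step in this assay is therefore expected to stay within the scatter, in no firm direction. Compound 3 is estimated at 11000 nM, ranging from 4000 nM to 30000 nM. For compound 3 this means an expected step of a 1.2-fold lower number from compound 1 to compound 3 (0.07 log units; within the scatter).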

Compound 3, concentration for 50% growth inhibition: 10800 nM
For compound 3 the middle estimate is 1.0-fold (0.01 log units) above the measured one; the range from low to high includes it.
By their numbers in this assay, from the lowest: compound 2; then compounds 3 and 1 (each within the scatter of the next).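

In this assay, thiophen-2-yl in place of phenyl on the carbon with a double bond to nitrogen gives a 1.2-fold lower number from compound 1 to compound 3 (0.08 log units; within the scatter), so this exchange of the aromatic ring produces no readable change. Thiophen-2-yl in place of 2-hydroxyphenyl gives a 5.7-fold higher number from compound 2 to compound 3 (0.75 log units; beyond the scatter), which leaves compound 2, with its hydroxy group, apart from the other two compounds. Nothing available explains either step. Going by these compounds, whether a hydroxy group on the thiophen-2-yl ring would lower the number as it does on phenyl remains open. So does whether a methoxy group or an amine could stand in for that hydroxy group.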